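The compounds below may be only part of what the source reports. "The series", "measured", "known", "first", "only" and "open" are said of these compounds alone.

Measured compounds in an ADME assay on Vero cells (Chlorocebus sabaeus) for cytotoxicity, read by resazurin assay, with a stated time of 3 days; on this read-out lower numbers stand for stronger inhibition and higher numbers for weaker inhibition:
compound 1 `COc1ccc(C(=O)Nc2cc3nc(C4CCCCC4)[nH]c3cc2N(C)C)cc1` gives > 100 ug/mL, a limit of the assay.
compound 2 `COc1ccc(C(=O)Nc2cc3nc(C4CCCCC4)[nH]c3cc2N2CCCC2)cc1` gives > 100 ug/mL, a limit of the assay.
compound 3 `CCCN(CCC)c1cc2[nH]c(C3CCCCC3)nc2cc1NC(=O)c1ccccc1` gives > 100 ug/mL, a limit of the assay.

Compound 1 stands only at a limit in this assay; every value shown for the series sits at that same limit (the limit of > 100 ug/mL in this assay, at which 3 of the 3 values shown sit). Among the measured compounds shown here, the one measured step, a step that the two limits leave unreadable from compound 1 to compound 2, is left unreadable by the two limits on either side of it, so its size cannot be told.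

Compound 4 `CCCCNC(=O)Nc1cc2nc(C3CCCCC3)[nH]c2cc1N(C)C` differs from compound 1 by butylamino in place of 4-methoxyphenyl on a carbonyl carbon. For the measured compounds named here, no measured step touches the carbonyl carbon or exchanges a 4-methoxyphenyl for a butylamino, so nothing measured bears on this change directly; what the series offers is the limit of > 100 ug/mL in this assay, at which 3 of the 3 values shown sit, with no compound yet reading below the limit. The expectation for compound 4 in this assay is therefore no step beyond the scatter, a step that the limit leaves unreadable from compound 1 to compound 4, meaning a value again at or past the limit. Compound 4 is estimated at 150 ug/mL, with a range from 60 ug/mL to 400 ug/mL.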

Compound 4, half-maximal inhibitory concentration: > 100 ug/mL
Compound 4: only a limit was reported; the forecaster's own chance of this, stated with the estimate: 80%; the middle value lies beyond the limit too.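

In this assay compound 4 gives > 100 ug/mL as a limit of the assay. No step can be read between compound 1 and compound 4; both stand only at a limit. The compounds shown leave open how far each lies past that limit, and which change would read below it: the limit of > 100 ug/mL in this assay, at which 4 of the 4 values shown sit.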